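Working notes: side-chain ester exchange in the series

The source may report more compounds than this note shows. Statements on the series, on what has been measured and on what is new or still open speak of the compounds shown alone.

Compound 1 `O=c1c(CCO)c(-c2ccccc2Cl)c2cc(Cl)ccc2n1-c1c(F)cccc1F` is the series member with the 2,6-difluorophenyl substituent on the ring nitrogen. In an ADME assay on HepG2 2.2.15 cells (Homo sapiens) for cytotoxicity (on this read-out higher numbers stand for lower toxicity in this test and lower numbers for higher toxicity in this test), compound 1 reaches only a limit, > 2300000 nM, and no number is known for it (the limit of > 2300000 nM in this assay, at which 1 of the 3 values shown sits). Compound 2 `O=CCc1c(-c2ccccc2Cl)c2cc(Cl)ccc2[nH]c1=O` carries the formyl group on the side chain; in this assay compound 2 gives 120000 nM. Compound 3 `COCC(=O)OCCc1c(-c2ccccc2Cl)c2cc(Cl)ccc2[nH]c1=O` has the side chain extended to the ester; in this assay compound 3 gives 74000 nM. Among the measured compounds shown here, the only measured step is a 1.6-fold lower number from compound 2 to compound 3 (0.21 log units; within the scatter), so compound 3 and compound 2 sit within the scatter of each other, and compound 1 contributes only its limit.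

Compound 4 `O=C(OCCc1c(-c2ccccc2Cl)c2cc(Cl)ccc2[nH]c1=O)c1ccc([N+](=O)[O-])cc1` differs from compound 3 in the acyl part of the ester: 4-nitrophenyl in place of methoxymethyl on a carbonyl carbon. For the measured compounds named here, no measured step exchanges one acyl group for another, so the single step from compound 2 to compound 3 is the only guide, and it was within the scatter. The step to compound 4 is therefore expected to be small, a 1.1-fold lower number from compound 3 to compound 4 (0.02 log units; within the scatter), with no change beyond the scatter. Compound 4 is estimated at 70000 nM, within 25000 nM to 200000 nM.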

Compound 4, half-maximal cytotoxic concentration: 1600000 nM
Beside the measured number, compound 4's estimate is 23-fold (1.36 log units) below it, outside the stated range (above it).
By their numbers in this assay, from the lowest: compounds 3 and 2 (each within the scatter of the next); then compound 4. At a limit, above all of these: compound 1.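

On the carbonyl carbon of the side-chain ester, the acyl part proves to matter in this assay: 4-nitrophenyl in place of methoxymethyl gives a 22-fold higher number from compound 3 to compound 4 (1.33 log units; beyond the scatter). The earlier step, a 1.6-fold lower number from compound 2 to compound 3 (0.21 log units; within the scatter), did not show a shift of this kind, and the new one points toward lower toxicity in this test. Nothing in the data at hand accounts for the size of this step.

Open, going by these compounds, is whether the step belongs to the aromatic ring or to the nitro group: an unsubstituted phenyl or a 4-aminophenyl on the same carbonyl carbon would separate the two. Also open, on these data alone, is whether the same acyl exchange carries over to a core with the 2,6-difluorophenyl substituent on the ring nitrogen, as in compound 1.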